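A few compounds are considered here, and "the series" means these few. Any claim that something is new, unique, unknown or untested is made for them only; others in the source may bear on it.

Among the compounds with values here, compound 2 `O=C(Nc1ccc(Sc2nc3ccccc3s2)c(Cl)c1)c1cc(Br)cc(Br)c1O` gives 76000 nM in an ADME assay on HEK293 cells (Homo sapiens) for cytotoxicity, read by reporter gene assay and resazurin assay, with a stated time of 48 h (a lower number here means that less compound is tolerated, a higher number that more compound is tolerated), the only actual number so far. Compound 1 `COc1ccccc1C(=O)Nc1ccc(Sc2nc3ccccc3s2)cc1`, which carries the 2-methoxyphenyl on a carbonyl carbon, gives > 100000 nM, and this is a limit of this assay, not a number. Compound 3 `COc1ccccc1C(=O)Nc1ccc(Sc2nc3ccccc3s2)c(Cl)c1` has not yet been measured. Its difference from compound 2 is 2-methoxyphenyl in place of 3,5-dibromo-2-hydroxyphenyl on a carbonyl carbon. Within the data shown here, no measured step gives the size of this swap. Among the measured compounds shown here, compound 1, with its limit of > 100000 nM, is the only guide. The expected move is small, a 1.3-fold higher number from compound 2 to compound 3 (0.12 log units; within the scatter), toward more compound tolerated and no larger than the scatter. For compound 3 the estimated value is 100000 nM, with an expected range of 50000 nM to 200000 nM.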

Compound 3, half-maximal cytotoxic concentration: > 100000 nM
Compound 3: a limit, no number; the forecaster's own chance of this, stated with the estimate: 60%; the middle value sits exactly at the limit.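

In this assay, 2-methoxyphenyl in place of 3,5-dibromo-2-hydroxyphenyl on a carbonyl carbon gives an at least 1.3-fold higher number from compound 2 to compound 3 (0.11 log units; that floor lies within the scatter), so this position now has its first step, though only as a floor and with no true size. Compound 3 carries a limit, not a number, and it shows that the chloro-bearing core with 2-methoxyphenyl reaches the same limit as the core of compound 1. The step of chloro in place of hydrogen on an aromatic carbon cannot be read, because compound 1 and compound 3 both rest on the same limit: the limit of > 100000 nM in this assay, at which 2 of the 3 values shown sit.

Open, on these data alone, is how a 2-hydroxyphenyl without the two bromines would read at this carbonyl carbon. Also open, as far as these compounds go, is whether an aryl group carrying an amine or a carboxylic acid there would give a number below the limit.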